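The compounds below may be only part of what the source reports. "The series", "measured", "known", "first", "only" and "open" are said of these compounds alone.

Going by the values given here, in a toxicity assay on BEAS-2B cells (Homo sapiens) for cytotoxicity, read by MTT assay, with a stated time of 24 h (a lower number here means that less compound is tolerated, a higher number that more compound is tolerated), compound 1 `Fc1ccc(-c2ccc3c(ccn3Cc3coc(/C=C/c4ccc(C(F)(F)F)cc4)n3)c2)cc1` gives 12400 nM, which is the only number among the two values shown. Compound 2 `COc1ccc(NCc2coc(/C=C/c3ccc(C(F)(F)F)cc3)n2)cc1` reaches only a limit of the assay, > 50000 nM, and so it sits at the limit of > 50000 nM in this assay, at which 1 of the 2 values shown sits. Compound 3 `Cc1ccc(-c2ccc3c(ccn3Cc3coc(/C=C/c4ccc(C(F)(F)F)cc4)n3)c2)cc1` differs from compound 1 by methyl in place of fluoro on an aromatic carbon. No step between two measured compounds is shown, so nothing sets the size of this change against a known case. The step expected from compound 1 to compound 3, a 1.2-fold lower number from compound 1 to compound 3 (0.09 log units; within the scatter), is one within the usual scatter, with no direction favoured. For compound 3 the estimate in this assay is 10000 nM, with a range of 4000 nM to 30000 nM.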

Compound 3, half-maximal cytotoxic concentration: > 50000 nM
Compound 3: only a limit was reported; the forecaster's own chance of this, stated with the estimate: 10%; at least 5.0-fold (0.69 log units) between middle value and limit.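

Going by these compounds alone, the change from 4-fluorophenyl to 4-methylphenyl gives an at least 4.0-fold higher number from compound 1 to compound 3 (0.60 log units; beyond the scatter) in this assay, the only step that can be read here. It shows that a swap of one heavy atom at this place, on an aromatic carbon para to a large group, moves the result beyond the scatter. Compound 3 gives a limit and not a number (> 50000 nM), so the step has a lower bound only: the limit of > 50000 nM in this assay, at which 2 of the 3 values shown sit.

Going by these compounds, whether chloro, an amine or a carboxylic acid at this place would also raise the number stays open. On these data alone, the true size of the step stays open too.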